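Chloro in place of trifluoromethoxy on the shared core

The source may report more compounds than this note shows. Statements on the series, on what has been measured and on what is new or still open speak of the compounds shown alone.

Values measured so far in an ADME assay for permeability, using PAMPA, with a stated time of 18 h, tested at 25 ug/mL (a higher number here means that the compound crosses the layer faster, a lower number that the compound crosses the layer more slowly), are these
compound 1 `FC(F)(F)c1ccc(CNC2CCN(Cc3ccccc3)C2)cc1` gives 6.3 10^-6 cm/s
compound 2 `Fc1ccc(CNC2CCN(Cc3ccccc3)C2)cc1` gives 4.2 10^-6 cm/s
compound 3 `FC(F)(F)Oc1ccc(CNC2CCN(Cc3ccccc3)C2)cc1` gives 6.9 10^-6 cm/s

Compound 3 cannot be separated from the other two compounds on these numbers, with a 1.1-fold higher number from compound 1 to compound 3 (0.04 log units; within the scatter) and a 1.6-fold higher number from compound 2 to compound 3 (0.22 log units; within the scatter) on record. Compound 4 `Clc1ccc(CNC2CCN(Cc3ccccc3)C2)cc1` differs from compound 3 by chloro in place of trifluoromethoxy on an aromatic carbon and carries chloro in place of trifluoromethoxy on an aromatic carbon. Among the compounds with values here, no measured compound carries chloro, so the nearest evidence is the other exchanges at that same place. Fluoro in place of trifluoromethyl gave a 1.5-fold lower number from compound 1 to compound 2 (0.18 log units; within the scatter) and trifluoromethyl gave way to trifluoromethoxy with a 1.1-fold higher number from compound 1 to compound 3 (0.04 log units; within the scatter) as the result. None of these steps leaves the scatter, and no step beyond the scatter is expected in this assay for this change either. The expected result is a 1.2-fold lower number from compound 3 to compound 4 (0.06 log units; within the scatter) as a small move with no firm direction. For compound 4 the estimate is 6 10^-6 cm/s with an expected range from 3.5 10^-6 cm/s to 10 10^-6 cm/s for a single measurement.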

Compound 4, apparent permeability: 4.1 10^-6 cm/s
Compound 4: middle estimate off by 1.5-fold (0.17 log units), on the high side; measured number inside the range.
By their numbers in this assay, from the lowest: compounds 4, 2, 1 and 3 (each within the scatter of the next).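

In this assay, the exchange to chloro on this aromatic carbon gives a 1.7-fold lower number from compound 3 to compound 4 (0.23 log units; within the scatter) against trifluoromethoxy, a 1.0-fold lower number from compound 2 to compound 4 (0.01 log units; within the scatter) against fluoro and a 1.5-fold lower number from compound 1 to compound 4 (0.19 log units; within the scatter) against trifluoromethyl, so no exchange among the four groups leaves the scatter. This position, para to a large group, now holds both chloro with its 1 heavy atom and trifluoromethoxy with its 5 heavy atoms, and that difference in size brings no separation in this read-out. No measurement shown bears on why the numbers fall as they do.

On these data alone, whether an amine or a carboxylic acid at this place would move the number beyond the scatter remains open. So does the question of whether changes elsewhere on the shared core would separate these compounds.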